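Trading a Methoxy Group for a Nitrile

The compounds below may be only part of what the source reports. "The series", "measured", "known", "first", "only" and "open" are said of these compounds alone.

Compound 1, `CNC(=O)c1cccn(Cc2ccccc2)c1=O`, is the simplest member of this small set. In a physicochemical assay for solubility (a higher number here means a more soluble compound, a lower number a less soluble compound), compound 1 gives 78 ug/mL. Compound 2, `CNC(=O)c1cc(C(=O)NC2CC2)cn(Cc2ccc(OC)cc2)c1=O`, is a more elaborate member of the same series built on the shared core. In this assay compound 2 reaches only a limit of the measurement, >= 143 ug/mL, not a true number. This is the limit of >= 143 ug/mL in this assay, at which 1 of the 2 values shown sits, so the actual solubility of compound 2 is not pinned down, only that it stands at or beyond that mark.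

Compound 3, `CNC(=O)c1cc(C(=O)NC2CC2)cn(Cc2cccc(C#N)c2)c1=O`, has not yet been measured. It differs from compound 2 in a single place: 3-cyanophenyl in place of 4-methoxyphenyl on a saturated chain carbon bound to an aromatic nitrogen. No measured pair among these compounds shows this same change, so the data give no direct guide to its effect on solubility. The step is expected to be modest, an at least 1.4-fold lower number from compound 2 to compound 3 (0.15 log units; that floor lies within the scatter), probably downward but possibly no larger than the scatter of repeated measurements. Compound 3 is therefore estimated at 100 ug/mL in this assay, with a plausible range from 30 ug/mL to 300 ug/mL.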

Compound 3, solubility: >= 148 ug/mL
Compound 3 was reported as a limit (the forecaster's own chance of this, stated with the estimate: 30%); at least 1.4-fold (0.17 log units) between middle value and limit.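

Among these compounds, compound 2 and compound 3 each give only a limit in this assay, not a true number, and no step between them can be read. From the compounds shown here alone, what stays open is the true solubility of each compound, and whether 3-cyanophenyl in place of 4-methoxyphenyl on a saturated chain carbon bound to an aromatic nitrogen changes it at all.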